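Substituent swap on the pendant aryl ring of compound 3

The compounds below may be only part of what the source reports. "The series", "measured", "known", "first", "only" and "open" are said of these compounds alone.

Compounds measured so far in a functional assay on MCF7 cells (Homo sapiens) for cytotoxicity, read by MTT assay, with a stated time of 72 h (a lower number here means a stronger inhibitor, a higher number a weaker inhibitor), are compound 1 `Cc1ccc(-c2ccc(C)n2-c2ccc(-c3nc4ccccc4s3)cc2)cc1`, compound 2 `COc1cc2nc(-c3ccc(-n4c(C)ccc4-c4ccc(C)cc4)cc3)sc2c(OC)c1OC` and compound 3 `COc1cc2nc(-c3ccc(-n4c(C)ccc4-c4ccc(F)cc4)cc3)sc2c(OC)c1OC`. In this assay compound 1 gives 3100 nM, compound 2 gives 3110 nM and compound 3 gives 2910 nM. Compound 3 holds the lowest of these numbers, but its distances to compound 1 and compound 2 are both within the scatter, so the three values cannot be ordered.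

Compound 4 `COc1ccc(-c2ccc(C)n2-c2ccc(-c3nc4cc(OC)c(OC)c(OC)c4s3)cc2)cc1` is not yet measured. It differs from compound 3 by methoxy in place of fluoro on an aromatic carbon. Going by the values given here, the single step that bears on this position is a 1.1-fold lower number from compound 2 to compound 3 (0.03 log units; within the scatter), which exchanged one small group for another on the same ring without moving the number beyond the scatter. No other change at this position is known. The expectation is therefore a step of a 1.0-fold higher number from compound 3 to compound 4 (0.01 log units; within the scatter) in this assay, no larger than the scatter, with no direction preferred.

For compound 4 the estimate is 3000 nM, with a range from 1500 nM to 6000 nM.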

Compound 4, half-maximal inhibitory concentration: 2200 nM
Compound 4: the middle estimate sits 1.4-fold (0.13 log units) above what was measured; the measured number falls inside the stated range.
By their numbers in this assay, from the lowest: compounds 4, 3, 1 and 2 (each within the scatter of the next).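

In this assay the change from 4-fluorophenyl to 4-methoxyphenyl gives a 1.3-fold lower number from compound 3 to compound 4 (0.12 log units; within the scatter) and stays small, and methoxy in place of methyl gives a 1.4-fold lower number from compound 2 to compound 4 (0.15 log units; within the scatter) on the same shared core. This position has now carried methyl, fluoro and methoxy without any step leaving the scatter, so the three groups cannot be ordered, even though methoxy brings one hydrogen-bond acceptor and fluoro brings none. No measurement of any property accompanies these values to account for this flat reading.

From the compounds shown here alone, whether an amine or a carboxylic acid at this position would move the number beyond the scatter remains open. Going by these compounds, a longer chain, such as butoxy in place of methoxy, is equally open.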